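Replacing tert-butyl with a dichlorophenyl-ethenyl arm

A few compounds are considered here, and "the series" means these few. Any claim that something is new, unique, unknown or untested is made for them only; others in the source may bear on it.

Measured so far in an assay on isolated protein with Bile acid receptor (Homo sapiens) as the target; on this read-out lower numbers stand for an effect already at smaller amounts and higher numbers for an effect only at larger amounts of compound:
Compound 1 `COC(=O)/C=C/c1cccc(N(Cc2ccc(Br)cc2)C(=O)C2CCCCC2)c1` gives > 1000 nM, a limit of the assay and not a number.
Compound 2 `COC(=O)/C=C/c1cccc(N(Cc2ccc(C(C)(C)C)cc2)C(=O)C2CCCCC2)c1` gives > 1000 nM, also a limit of the assay.

Compound 2 therefore stands at the limit, and the step that the two limits leave unreadable from compound 1 to compound 2 cannot be read because of the limit of > 1000 nM in this assay, at which 2 of the 2 values shown sit. Compound 3 `COC(=O)/C=C/c1cccc(N(Cc2ccc(/C=C/c3c(Cl)cccc3Cl)cc2)C(=O)C2CCCCC2)c1` differs from compound 2 by 2-(2,6-dichlorophenyl)ethenyl in place of tert-butyl on an aromatic carbon. For the measured compounds named here, no measured step gives a readable size for such a change, so no direction can be expected from the data, and another limit is quite possible. Compound 3 is expected at 1500 nM, within 300 nM to 8000 nM. For compound 3 this means an expected step that the limit leaves unreadable from compound 2 to compound 3.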

Compound 3, half-maximal effective concentration: 150 nM
Compound 3: middle estimate off by 10-fold (1.00 log units), on the high side; measured number outside the range, below it.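

In this assay, the 2-(2,6-dichlorophenyl)ethenyl arm gives an at least 6.6-fold lower number from compound 2 to compound 3 (0.82 log units; beyond the scatter), and measured against bromo it gives an at least 6.6-fold lower number from compound 1 to compound 3 (0.82 log units; beyond the scatter). This position can therefore move the read-out, and a much larger group than bromo or tert-butyl yields a readable number here, while the step between those two smaller groups cannot be read.

From the compounds shown here alone, the full size of both steps stays open because the two earlier compounds sit at a limit: the limit of > 1000 nM in this assay, at which 2 of the 3 values shown sit. Also open, going by these compounds, is whether the ethenyl link and the two chlorines matter, or whether a plain phenyl or an amine here would give a similar number.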